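This account rests on a few compounds, and the source may have more. Where it says the series, first, only, none or still open, it means among the compounds named here.

This piece follows one change made to a sulfonamide series, judged in an ADME assay on HCT-116 cells (Homo sapiens) for cytotoxicity, read by CellTiter-Glo, with a stated time of 72 h; on this read-out higher numbers stand for weaker inhibition and lower numbers for stronger inhibition. Compound 1 `Cc1noc(C)c1S(=O)(=O)N1CCC(N2CCC(C)CC2)CC1` is the starting point. In this assay compound 1 gives > 10000 nM, which is a limit of the assay rather than a number. Two related compounds have also been run. Compound 2 `Cc1cc(C)c(S(=O)(=O)N2CCC(N3CCC(CCO)CC3)CC2)c(C)c1` gives > 5000 nM in this assay, again a limit. Compound 3 `CC1CCN(C2CCN(S(=O)(=O)c3ccccc3-c3ccc(Cl)cc3)CC2)CC1` gives > 5000 nM in this assay, also a limit. All three measured values therefore sit at limits: the limit of > 10000 nM in this assay, at which 1 of the 3 values shown sits, and (the limit of > 5000 nM in this assay, at which 2 of the 3 values shown sit). Going by the values given here, compound 1 stands among them with nothing that sets it apart, and no step between measured compounds can be sized.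

Compound 4 `CC1CCN(C2CCN(S(=O)(=O)c3cccc(N)c3)CC2)CC1` has not yet been measured in this assay. It differs from compound 1 in one place: 3-aminophenyl in place of 3,5-dimethyl-1,2-oxazol-4-yl on a sulfonyl sulfur. Among the compounds with values here, with every measured value at a limit, there is no step to lean on. The expectation is that this change moves the read-out by no more than the usual scatter, so compound 4 is expected to come back as a limit as well. The estimated step is a step that the limit leaves unreadable from compound 1 to compound 4. Compound 4 is expected to give 15000 nM in this assay, within a range from 5000 nM to 50000 nM.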

Compound 4, half-maximal inhibitory concentration: > 5000 nM
Compound 4 was reported as a limit; the forecaster's own chance of this, stated with the estimate: 85%; the middle value does not contradict the limit.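

In this assay compound 4 gives > 5000 nM, which is a limit of the assay and not a number. Compound 1 gives > 10000 nM, also a limit, so no step can be read between these two compounds. The compounds shown leave open how strongly any of them inhibits these cells, and whether 3-aminophenyl in place of 3,5-dimethyl-1,2-oxazol-4-yl changes the read-out at all.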